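Estimating the effect of a larger ether on half-life

The source may hold more compounds than are shown below. What is called first, only, known or untested is meant among the compounds shown, and "the series" means these compounds.

Compound 1 `CC(C)(C)c1ccc(C(=O)NCc2ccc(NS(=O)(=O)C3CC3)cc2Cl)cc1` gives 0.55 h
Compound 2 `COc1ccc(C(=O)NCc2ccc(NS(C)(=O)=O)cc2Cl)cc1` gives 4.5 h

In an ADME assay on microsomes from liver (Rattus norvegicus, strain Sprague-Dawley) for metabolic stability, read by HPLC, using NADPH, with stated times of 5 min and 60 min, tested at 10 uM (on this read-out lower numbers stand for a shorter-lived compound and higher numbers for a longer-lived compound), compound 2 has the higher of the two numbers, and compound 1 lies below it by more than the usual scatter. Compound 3 `CC(C)Oc1ccc(C(=O)NCc2ccc(NS(C)(=O)=O)cc2Cl)cc1` differs from compound 2 by one change isopropyl in place of methyl on an oxygen on an aromatic ring with isopropyl in place of methyl on an oxygen on an aromatic ring. Among the measured compounds shown here, no measured pair shows this change alone, so any forecast is uncertain. For the measured compounds named here, compound 1 at 0.55 h offers the only lower number, though it differs from compound 2 in more than one place. The expected move a 2.5-fold lower number from compound 2 to compound 3 (0.40 log units; beyond the scatter) is a modest fall in half-life, slightly beyond the scatter. Compound 3 is estimated at 1.8 h within an expected range of 0.7 h to 4 h in this measurement.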

Compound 3, half-life: 1.85 h
For compound 3 the middle estimate is 1.0-fold (0.01 log units) below the measured one, within the range that was stated.
By their numbers in this assay, from the lowest: compound 1; then compound 3; then compound 2.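

Read on its own, the change from methoxy to isopropoxy gives in this assay a 2.4-fold lower number from compound 2 to compound 3 (0.39 log units; beyond the scatter), so this oxygen substituent alone can shift half-life by more than the scatter. Among the compounds shown here, this is the first reading at this position in which nothing else in the molecule differs. No measurement shown explains why the half-life falls. Still open, as far as these compounds go, is how an ethoxy group or a longer chain on this oxygen would compare. A trifluoromethoxy group in this place is equally untested among the compounds shown.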